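This account rests on a few compounds, and the source may have more. Where it says the series, first, only, none or still open, it means among the compounds named here.

Of the compounds shown here, three of a shared core have been measured in a functional assay (Oryctolagus cuniculus) for antagonist activity at platelet-activating factor receptor (Cavia porcellus); a lower number here means a stronger inhibitor, a higher number a weaker inhibitor. Compound 1 `O=C(c1ccn2c1CSC2c1cccnc1)c1c[nH]c2cccc(O)c12` gives 327 nM. Compound 2 `O=C(c1ccn2c1CSC2c1cccnc1)c1c[nH]c2cc(-c3ccc(F)cc3)ccc12` gives 75 nM. Compound 3 `CN(C)C(=O)n1cc(C(=O)c2ccn3c2CSC3c2cccnc2)c2ccccc21` gives 95 nM, the second highest of the three numbers; its value sits within the scatter of that of compound 2, while the gap to compound 1 lies beyond the scatter, compound 3 giving the lower number.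

Compound 4 `CN(C)C(=O)n1cc(C(=O)c2ccn3c2CSC3c2cccnc2)c2ccc(OCc3ccccc3)cc21` is still to be measured in this assay. It differs from compound 3 in one place: benzyloxy in place of hydrogen on an aromatic carbon. For the measured compounds named here, no measured pair shows this change directly. What the set does show is that a bulky ring substituent on the same fused two-ring system is tolerated, because compound 2 gives 75 nM with such a group. On this basis the step is expected to be small, toward a lower number or none beyond the scatter, and the change from compound 3 to compound 4 is estimated as a 1.6-fold lower number from compound 3 to compound 4 (0.20 log units; within the scatter). Compound 4 is therefore expected to give about 60 nM, with a likely range from 20 nM to 200 nM.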

Compound 4, inhibition constant: 17 nM
For compound 4 the middle estimate is 3.5-fold (0.55 log units) above the measured one, and the stated range ends above it.
By their numbers in this assay, from the lowest: compound 4; then compounds 2 and 3 (each within the scatter of the next); then compound 1.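

In this assay, benzyloxy in place of hydrogen on this aromatic carbon gives a 5.6-fold lower number from compound 3 to compound 4 (0.75 log units; beyond the scatter), so the change does more than leave the number unmoved. For the compounds shown here, this is the first direct reading at this position of the fused system of two rings, as no earlier pair of compounds differed in one place. No supporting measurement bears on why the step is this large.

Going by these compounds alone, the single step leaves open whether the gain follows from the oxygen, the benzene ring or the two together, and a methoxy group or a benzyl group on the same carbon would separate them. It also leaves open how an amine or a carboxylic acid would fare there, and whether benzyloxy would give a similar step on another carbon of this ring.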